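Swapping the fluorophenyl for a methylthiophene in a hydroxamate series

A few compounds are considered here, and "the series" means these few. Any claim that something is new, unique, unknown or untested is made for them only; others in the source may bear on it.

Measured compounds:
compound 1 `Cc1ccc(-c2nc(CNc3ccc(C(=O)NO)cc3)n(-c3ccccc3)n2)cc1`, 62.2%
compound 2 `O=C(NO)c1ccc(NCc2nc(-c3ccc(Cl)cc3)nn2-c2ccccc2)cc1`, 67.2%
compound 3 `O=C(NO)c1ccc(NCc2nc(-c3ccc(F)cc3)nn2-c2ccccc2)cc1`, 70.9%

All three were tested in an assay on Sf9 cells for inhibition of protein deacetylase HDAC6 (Homo sapiens), read by fluorescence, with a stated time of 40 min, tested at 100 nM; a higher number here means more inhibition at the concentration tested (going by the name of the read-out), a lower number less inhibition. They share one core and differ only in the group on one aromatic ring: methyl in compound 1, chloro in compound 2, fluoro in compound 3. Compound 3 gives the highest number of the three, yet a number 8.7 percentage points higher from compound 1 to compound 3 (within the scatter) and a number 3.7 percentage points higher from compound 2 to compound 3 (within the scatter) both lie within the scatter, and so does a number 5 percentage points higher from compound 1 to compound 2 (within the scatter), so no ranking among them can be read from these numbers.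

Compound 4 `Cc1ccc(-c2nc(CNc3ccc(C(=O)NO)cc3)n(-c3ccccc3)n2)s1` is the next step from compound 3. Its change is 5-methylthiophen-2-yl in place of 4-fluorophenyl on an aromatic carbon. Among the measured compounds shown here, no measured step exchanges the whole ring at this position; the three steps only vary the group carried by that ring, and each of them stayed within the scatter. They therefore suggest that varying this part of the molecule has so far left the number in this assay level, though a ring exchange is a larger change than any of them. For compound 4 the expected outcome is no step beyond the scatter, a number 5.9 percentage points lower from compound 3 to compound 4 (within the scatter), and its inhibition in this assay is estimated at 65% with a range from 48% to 80%.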

Compound 4, a percentage reported as inhibition, at one concentration (the size of the read-out at that concentration, not a potency): 79.7%
Beside the measured number, compound 4's estimate is 14.7 percentage points below it, within the range that was stated.
By their numbers in this assay, from the lowest: compounds 1, 2, 3 and 4 (each within the scatter of the next, the first and the last beyond it).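

In this assay this position on the shared core accepts an exchange of the whole ring, not only of the group that ring carries: 5-methylthiophen-2-yl in place of 4-fluorophenyl gives a number 8.8 percentage points higher from compound 3 to compound 4 (within the scatter) and so leaves the two compounds level. Among the compounds shown here, the same ring also gives the first steps in this set that pass the scatter, a number 12.5 percentage points higher from compound 2 to compound 4 (beyond the scatter) and a number 17.5 percentage points higher from compound 1 to compound 4 (beyond the scatter) and both modest, while all steps among the three phenyl compounds stayed within it. Nothing in the available data explains why these steps take the size they do.

On these data alone, it remains open whether the five-membered ring or its methyl group matters more, and an unsubstituted thiophen-2-yl ring, a 5-chlorothiophen-2-yl ring or a furan ring would help to separate the two. Also open, as far as these compounds go, is whether this carbon needs an aromatic ring at all, which a longer alkyl chain or an amine in that place would test, and whether the picture at this single concentration would hold in a full potency measurement.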